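Trading the Ring for a Diethoxy Chain

This account rests on a few compounds, and the source may have more. Where it says the series, first, only, none or still open, it means among the compounds named here.

Three compounds built around a shared core carry different side groups on the chain attached to the sulfur. Compound 1 `COc1ccc(-c2nc(SCC3C[C@@](C)(O)CC(=O)O3)[nH]c2-c2ccc(OC)cc2)cc1` and compound 2 `C[C@@]1(O)CC(=O)OC(CSc2nc(-c3ccccc3Cl)c(-c3ccccc3Cl)[nH]2)C1` each carry a ring-bearing side chain, and compound 3 `O=C1CCC(CSc2nc(-c3ccccc3)c(-c3ccccc3)[nH]2)N1` does as well. In an assay on microsomes from liver for inhibition of sterol O-acyltransferase 1 (Rattus norvegicus) (a higher number here means a weaker inhibitor, a lower number a stronger inhibitor), compound 1 gives 340 nM, compound 2 gives 140 nM and compound 3 gives 360 nM. Compound 3 therefore stands at the highest of the three numbers; its gap to compound 1 lies within the usual scatter, whereas compound 2 sits clearly lower, beyond the scatter.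

Compound 4 `CCOC(CCSc1nc(-c2ccccc2)c(-c2ccccc2)[nH]1)OCC` has not been measured. It differs from compound 3 in one place: 2,2-diethoxyethyl in place of 5-oxopyrrolidin-2-yl on a saturated chain carbon bound to a sulfur. The ring and its hydrogen-bond donor are gone in favour of an open chain. Within the data shown here, no measured pair shows an exchange of this kind, so the size of the step is uncertain; a modest rise in the number, toward weaker inhibition, seems somewhat more likely than a fall, though a step within the scatter is also plausible. The expected step is a 1.7-fold higher number from compound 3 to compound 4 (0.22 log units; within the scatter). In this assay compound 4 is expected to give 600 nM, with a likely range from 180 nM to 2500 nM.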

Compound 4, half-maximal inhibitory concentration: 69 nM
The estimate for compound 4 lay 8.7-fold (0.94 log units) above the measured number; measured number outside the range, below it.
By their numbers in this assay, from the lowest: compound 4; then compound 2; then compounds 1 and 3 (each within the scatter of the next).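

Putting 2,2-diethoxyethyl in place of 5-oxopyrrolidin-2-yl on a saturated chain carbon bound to a sulfur gives a 5.2-fold lower number from compound 3 to compound 4 (0.72 log units; beyond the scatter) and this step lies beyond the usual scatter. For this pair, then, neither the ring nor its hydrogen-bond donor is required for inhibition at this position, and the open chain with 0 hydrogen-bond donors gives the lower number. No measurement here accounts for the size of this step.

The exchange removes the ring and the donor and adds the two ethoxy groups in a single move, so the compounds shown leave open which of these changes matters. Going by these compounds, a plain butyl chain or a 3-methoxypropyl chain at the same place would begin to separate them, and whether the gain carries over to the cores of compound 1 and compound 2 also remains open.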